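Adding one carbon to a methoxy group

The compounds below may be only part of what the source reports. "The series", "measured", "known", "first", "only" and "open" are said of these compounds alone.

Compound 1 `COc1cc(-c2nc(C)sc2-c2ccc(C)cc2)cc(OC)c1OC`: 1510 nM
Compound 2 `COc1ccc(-c2sc(C)nc2-c2cc(OC)c(OC)c(OC)c2)cc1`: 3430 nM

In a functional assay on HL-60 cells (Homo sapiens) for antiproliferative activity, read by MTT assay, with a stated time of 72 h (a lower number here means a stronger inhibitor, a higher number a weaker inhibitor), compound 2 gives 3430 nM, the higher of the two numbers, which makes it the weaker inhibitor of the pair. Compound 3 `CCOc1ccc(-c2sc(C)nc2-c2cc(OC)c(OC)c(OC)c2)cc1` differs from it in one place: methyl in place of hydrogen on a saturated chain carbon bound to an oxygen on an aromatic ring. A methyl replaces a hydrogen on a saturated chain carbon bound to an oxygen on an aromatic ring, turning methoxy into ethoxy.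

Among the measured compounds shown here, only one measured step bears on this, and only loosely, since it also involves the methoxy group: a 2.3-fold higher number from compound 1 to compound 2 (0.36 log units; beyond the scatter). That step was modest, and no change from methoxy to ethoxy has been measured, so the direction is uncertain. A small further rise in this assay is expected, probably within the scatter. The expected size is a 1.2-fold higher number from compound 2 to compound 3 (0.07 log units; within the scatter). For compound 3 the estimate is 4000 nM, with an expected range of 1200 nM to 13000 nM.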

Compound 3, half-maximal inhibitory concentration: 253 nM
Compound 3: middle estimate off by 16-fold (1.20 log units), on the high side; measured number outside the range, below it.
By their numbers in this assay, from the lowest: compound 3; then compound 1; then compound 2.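

In this assay this position proves far more sensitive than the earlier pair suggested: one added methyl, turning methoxy into ethoxy, gives a 14-fold lower number from compound 2 to compound 3 (1.13 log units; beyond the scatter) and is a large change from a single carbon. Ethoxy also outdoes the methyl of compound 1, with a 6.0-fold lower number from compound 1 to compound 3 (0.78 log units; beyond the scatter) as the step, so the numbers do not move steadily as the group grows from methyl to methoxy to ethoxy. Nothing available here explains why this one carbon matters so much.

The compounds shown leave open whether a longer chain such as propoxy or butoxy would extend this gain or reverse it. They also do not tell how a branched isopropoxy group, or an amine at the end of the chain, would behave at this place.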